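A Methoxy Group in Place of Hydrogen

The source may report more compounds than this note shows. Statements on the series, on what has been measured and on what is new or still open speak of the compounds shown alone.

Among the measured compounds shown here, in a functional assay for inhibition, with Homo sapiens as the target (on this read-out higher numbers stand for weaker inhibition and lower numbers for stronger inhibition), compound 1 `Cc1cc2c(cc1C(=O)N=C(N)N)S(=O)(=O)CC2C` gives 182 nM, while compound 2 `Cc1cc2c(cc1C(=O)N=C(N)N)S(=O)(=O)CC2` gives 587 nM, the highest of the two numbers so far. Compound 3 `COC1CS(=O)(=O)c2cc(C(=O)N=C(N)N)c(C)cc21` has methoxy in place of hydrogen on a saturated ring carbon of compound 2: methoxy in place of hydrogen on a saturated ring carbon. For the measured compounds named here, the one measured step that bears on this is the modest 3.2-fold higher number from compound 1 to compound 2 (0.51 log units; beyond the scatter), with hydrogen in place of methyl on a saturated ring carbon. Read in reverse, that step points to a somewhat lower number, though no methoxy analogue has been measured. The expected change is a 2.0-fold lower number from compound 2 to compound 3 (0.29 log units; within the scatter). The estimate for compound 3 is 300 nM, with an expected range of 110 nM to 800 nM.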

Compound 3, half-maximal inhibitory concentration: 208 nM
Compound 3: the middle estimate sits 1.4-fold (0.16 log units) above what was measured; measured number inside the range.
By their numbers in this assay, from the lowest: compounds 1 and 3 (each within the scatter of the next); then compound 2.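

In this assay, the saturated ring carbon two ring bonds from the ring sulfur responds to a substituent other than methyl, with methoxy in place of hydrogen giving (a 2.8-fold lower number from compound 2 to compound 3 (0.45 log units; beyond the scatter)). Methoxy and methyl cannot be told apart at this carbon (a 1.1-fold higher number from compound 1 to compound 3 (0.06 log units; within the scatter)), so the two groups read alike here. Nothing available explains this result. The compounds shown leave open how a hydroxyl, an amine or a longer chain such as ethoxy would read on this same carbon.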